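Swapping nitro for methoxycarbonyl in compound 3

The source may report more compounds than this note shows. Statements on the series, on what has been measured and on what is new or still open speak of the compounds shown alone.

Measured so far in a functional assay on HCT-116 cells (Homo sapiens) for inhibition, read by MTT assay, with a stated time of 48 h; a higher number here means a weaker inhibitor, a lower number a stronger inhibitor:
Compound 1 `C/C=C/C(=O)N(Cc1ccc(OC)c([N+](=O)[O-])c1)c1cc(OC)c(OC)c(OC)c1` gives 670 nM
Compound 2 `COc1cc(NCc2ccccc2)cc(OC)c1OC` gives > 80000 nM as a limit of the assay
Compound 3 `COc1ccc(CNc2cc(OC)c(OC)c(OC)c2)cc1[N+](=O)[O-]` gives 18200 nM

Only two of these entries are actual numbers, and compound 3 holds the higher one. Going by the values given here, compound 1 at 670 nM is its only neighbour on that scale.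

The next compound is compound 4 `COC(=O)c1cc(CNc2cc(OC)c(OC)c(OC)c2)ccc1OC` and it differs from compound 3 in one place. The change is methoxycarbonyl in place of nitro on an aromatic carbon and it puts methoxycarbonyl in place of nitro on an aromatic carbon, ortho to a methoxy group.

Among the compounds with values here, no measured step covers this swap. Within the data shown here, the one measured step, a 27-fold higher number from compound 1 to compound 3 (1.43 log units; beyond the scatter), is large, but it puts hydrogen in place of (prop-1-en-1-yl)carbonyl on a nitrogen and leaves the nitro untouched, so its size does not carry over. Compound 2 carries neither the nitro nor that methoxy group, and its > 80000 nM is only a limit. Compound 3 at 18200 nM therefore remains the sole anchor.

The expected step in this assay is small and toward a higher number, estimated as a 1.6-fold higher number from compound 3 to compound 4 (0.22 log units; within the scatter) and no larger. Compound 4 is estimated at 30000 nM with 10000 nM to 80000 nM as the expected range.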

Compound 4, half-maximal inhibitory concentration: 38100 nM
Compound 4: the middle estimate sits 1.3-fold (0.10 log units) below what was measured; the measured number falls inside the stated range.
By their numbers in this assay, from the lowest: compound 1; then compound 3; then compound 4. At a limit, above all of these: compound 2.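

In this assay, the position ortho to a methoxy group proves responsive to substitution: methoxycarbonyl in place of nitro gives a 2.1-fold higher number from compound 3 to compound 4 (0.32 log units; beyond the scatter), a modest step that lies just beyond the scatter. Going by these compounds alone, this is the first measured change at this aromatic carbon, and it shows that the nitro can be exchanged with only a modest loss, while the earlier step concerned the nitrogen and left this carbon untouched. The two groups match in their counts of hydrogen-bond donors and acceptors and each has one double bond outside aromatic rings, so these counts do not separate them, and nothing measured here bears on why the number moves.

The compounds shown leave open how an amine, a carboxylic acid or a nitrile on this aromatic carbon would read, so a single swap cannot yet describe the position as a whole. Also open, as far as these compounds go, is whether the step of a 27-fold higher number from compound 1 to compound 3 (1.43 log units; beyond the scatter) would be of similar size with methoxycarbonyl in place of nitro, since (prop-1-en-1-yl)carbonyl on the nitrogen appears here only alongside the nitro.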